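Replacing a Nitrile by Methyl: Expected Effect on Cytotoxicity

The source may hold more compounds than are shown below. What is called first, only, known or untested is meant among the compounds shown, and "the series" means these compounds.

In a functional assay on MT2 cells (Homo sapiens) for cytotoxicity (on this read-out lower numbers stand for higher toxicity in this test and higher numbers for lower toxicity in this test), three compounds have been measured so far. Compound 1 `CCc1ccc(Nc2nccs2)cc1OCC=C(C)C` gives 31000 nM, compound 2 `CC(C)=CCOc1cc(Nc2nccs2)ccc1C#N` gives 500 nM, and compound 3 `CC(C)=CCOc1cc(Nc2ccccn2)ccc1C#N` gives 290 nM. Compound 2 stands second highest of these three numbers; its nearest neighbour is compound 3, within the scatter, while compound 1 lies far off with a much higher number, beyond the scatter.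

The change from compound 2 to compound 4 `CC(C)=CCOc1cc(Nc2nccs2)ccc1C` is methyl in place of cyano on an aromatic carbon. Going by the values given here, one measured step bears directly on this place: a 62-fold lower number from compound 1 to compound 2 (1.79 log units; beyond the scatter), where an ethyl group was exchanged for cyano and the number fell sharply. Methyl, like ethyl, brings no triple bond and no hydrogen-bond acceptor, so removing the cyano is expected to move the number back toward that of compound 1, though not necessarily all the way, since methyl is not ethyl. The step of a 1.7-fold lower number from compound 2 to compound 3 (0.24 log units; within the scatter) concerns a different part of the molecule and gives no guidance here.

Compound 4 is therefore expected to show a large rise in the half-maximal cytotoxic concentration, a 24-fold higher number from compound 2 to compound 4 (1.38 log units; beyond the scatter). The estimate for compound 4 is 12000 nM, within a range from 2500 nM to 50000 nM.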

Compound 4, half-maximal cytotoxic concentration: 17000 nM
Compound 4: middle estimate off by 1.4-fold (0.15 log units), on the low side; measured number inside the range.
By their numbers in this assay, from the lowest: compounds 3 and 2 (each within the scatter of the next); then compounds 4 and 1 (each within the scatter of the next).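

In this assay the step of a 34-fold higher number from compound 2 to compound 4 (1.53 log units; beyond the scatter) is large and beyond the scatter, so, with only this one place changed, the nitrile goes with the much lower number and methyl does not. The step of a 1.8-fold lower number from compound 1 to compound 4 (0.26 log units; within the scatter) lies within the scatter, so methyl and ethyl on this aromatic carbon cannot be told apart in this test, and the earlier large step is not specific to ethyl. Nothing measured here explains why the nitrile compound gives the lower number.

Going by these compounds, it remains open whether another group at this place, such as an amide, a carboxylic acid or a chlorine atom, would give a number close to that of the nitrile or close to those of the alkyl groups. On these data alone, it is also open whether methyl in place of cyano would produce a similar rise in compound 3, which carries pyridin-2-yl instead of 1,3-thiazol-2-yl.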